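Working notes on a small series and one unmeasured compound

This account rests on a few compounds, and the source may have more. Where it says the series, first, only, none or still open, it means among the compounds named here.

Measured so far:
- Compound 1 `Cc1cc(C)cc(Sc2cccc(N)c2C#N)c1`; in a functional assay on MT4 cells (Homo sapiens) for cytotoxicity (a lower number here means a stronger inhibitor, a higher number a weaker inhibitor), compound 1 gives > 2000 nM, which is a limit.
- Compound 2 `COc1cc(C)cc(Sc2cccc(N)c2C#N)c1`; in this assay compound 2 gives 10000 nM.
- Compound 3 `COc1ccccc1[S+]([O-])c1cccc(N)c1C#N`; in this assay compound 3 gives > 200000 nM, which is a limit.

Compounds 1 and 2 share a core and differ in one place: methyl in place of methoxy on an aromatic carbon. The step from compound 2 to compound 1 in this assay reads a step that the limit leaves unreadable from compound 2 to compound 1; it cannot be sized because of the limit of > 2000 nM in this assay, at which 1 of the 3 values shown sits. Compound 3 has a different core, and the difference between the two cores is not broken down here. For compound 3 only a limit is known, set by the limit of > 200000 nM in this assay, at which 1 of the 3 values shown sits.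

The unmeasured compound 4 `Cc1ccccc1[S+]([O-])c1cccc(N)c1C#N` is related to compound 3 by methyl in place of methoxy on an aromatic carbon. Within the data shown here, this is the same kind of change as the one from compound 2 to compound 1, but not the same: in compound 4 it sits ortho to a large group, while in compound 1 it sits meta to a large group and meta to a methyl group.

For compound 4 in this assay the step from compound 3 is expected to be a number no higher from compound 3 to compound 4 (the limit leaves the size open), resting on the limit seen for compound 3 in this assay, > 200000 nM, and on the unreadable step that the limit leaves unreadable from compound 2 to compound 1, which gives no sign that this kind of change moves the value far. Compound 4 is therefore estimated at 200000 nM, with a range from 50000 nM to 800000 nM, and most likely the result will again be only a limit.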

Compound 4, half-maximal inhibitory concentration: > 200000 nM
Compound 4: no number, only a limit (the forecaster's own chance of this, stated with the estimate: 80%); the middle value sits exactly at the limit.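

In this assay compound 4 gives > 200000 nM, which is a limit. Compound 3 also has only a limit, so no step can be read between compound 3 and compound 4, and none between compound 2 and compound 1: the limit of > 200000 nM in this assay, at which 2 of the 4 values shown sit.

The compounds shown leave open how far methyl in place of methoxy moves the value in this assay on either core.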